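A few compounds are considered here, and "the series" means these few. Any claim that something is new, unique, unknown or untested is made for them only; others in the source may bear on it.

Three compounds share one core and differ only in the group on a saturated chain carbon bound to a sulfur. In a functional assay on HCT-116 cells (Homo sapiens) for antiproliferative activity, read by MTT assay, with a stated time of 72 h (a higher number here means a weaker inhibitor, a lower number a stronger inhibitor), compound 1 `C/C(C#Cc1ccccc1)=N\N/C(N)=N/S(=O)(=O)c1cc(C)c(Cl)cc1SCc1ccccc1C` gives 142000 nM. Compound 2 `C/C(C#Cc1ccccc1)=N\N/C(N)=N/S(=O)(=O)c1cc(C)c(Cl)cc1SCc1cccc(C(F)(F)F)c1` gives 14000 nM in this assay, and compound 3 `C/C(C#Cc1ccccc1)=N\N/C(N)=N/S(=O)(=O)c1cc(C)c(Cl)cc1SCc1ccccc1Cl` gives 129000 nM in this assay. Compound 3 thus holds the second highest of the three numbers; its nearest neighbour is compound 1, separated by a 1.1-fold lower number from compound 1 to compound 3 (0.04 log units; within the scatter), and its furthest is compound 2, separated by a 9.2-fold higher number from compound 2 to compound 3 (0.96 log units; beyond the scatter). Compound 4 `C/C(C#Cc1ccccc1)=N\N/C(N)=N/S(=O)(=O)c1cc(C)c(Cl)cc1SCc1cccc2ccccc12` has not been measured. The change from compound 3 to compound 4 is naphthalen-1-yl in place of 2-chlorophenyl on a saturated chain carbon bound to a sulfur. Two measured steps alter this same place, a 10-fold lower number from compound 1 to compound 2 (1.01 log units; beyond the scatter) and a 9.2-fold higher number from compound 2 to compound 3 (0.96 log units; beyond the scatter), both sizeable, whereas a 1.1-fold lower number from compound 1 to compound 3 (0.04 log units; within the scatter) is small. Going by the values given here, no measured step brings in a naphthalen-1-yl group, so the direction is uncertain, and the spread of the three numbers sets the width of the range. Compound 4 is expected to give about 60000 nM, with a range from 12000 nM to 200000 nM. The step this estimate implies is a 2.2-fold lower number from compound 3 to compound 4 (0.33 log units; beyond the scatter).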

Compound 4, half-maximal inhibitory concentration: 105000 nM
Compound 4: the middle estimate sits 1.8-fold (0.24 log units) below what was measured, and the stated range covers the measured number.
By their numbers in this assay, from the lowest: compound 2; then compounds 4, 3 and 1 (each within the scatter of the next).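

In this assay, the change to naphthalen-1-yl on a saturated chain carbon bound to a sulfur leaves the number in the same group as the two single-ring substituents, with a 1.2-fold lower number from compound 3 to compound 4 (0.09 log units; within the scatter) and a 1.4-fold lower number from compound 1 to compound 4 (0.13 log units; within the scatter). Compound 4 remains well separated from the 3-(trifluoromethyl)phenyl compound, with a 7.5-fold higher number from compound 2 to compound 4 (0.88 log units; beyond the scatter). Adding a second aromatic ring therefore does not reproduce the separation seen for compound 2, which stands apart from compounds 1, 3 and 4 in this set.

No supporting information is available to explain this separation. The compounds shown leave open whether 3-chlorophenyl, 3-methylphenyl or naphthalen-2-yl groups would fall with compound 2 or with the other three compounds.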